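This account rests on a few compounds, and the source may have more. Where it says the series, first, only, none or still open, it means among the compounds named here.

Within the data shown here, compound 1 `O=C(NC(=S)NNc1ncnc2ccccc12)c1ccccc1` stands lowest of the two numbers so far in a functional assay on CNE-2 cells (Homo sapiens) for cytotoxicity, read by MTT assay, with a stated time of 72 h (on this read-out lower numbers stand for stronger inhibition and higher numbers for weaker inhibition), where compound 1 gives 1490 nM. Among the measured compounds shown here, its only measured companion is compound 2 `O=C(NC(=S)NNc1ncnc2ccccc12)c1ccc(C(F)(F)F)cc1`, which in this assay gives 22500 nM; the step of a 15-fold higher number from compound 1 to compound 2 (1.18 log units; beyond the scatter) went with trifluoromethyl in place of hydrogen on an aromatic carbon of the benzoyl ring. Compound 3 `O=C(NC(=S)NNc1ncnc2ccccc12)c1ccccc1Cl` differs from compound 1 by chloro in place of hydrogen on an aromatic carbon, the group sitting on an aromatic carbon of a six-membered aromatic ring of carbon only, ortho to a large group, so that phenyl becomes 2-chlorophenyl. For the measured compounds named here, the one step that bears on this change, a 15-fold higher number from compound 1 to compound 2 (1.18 log units; beyond the scatter), was large and upward, though it involved a different group at a different place on the same ring, so it sets only a loose precedent. Compound 3 is therefore expected to give 3500 nM, between 1200 nM and 12000 nM, an expected step of a 2.3-fold higher number from compound 1 to compound 3 (0.37 log units; beyond the scatter) upward but more modest than the trifluoromethyl one.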

Compound 3, half-maximal inhibitory concentration: 6090 nM
The estimate for compound 3 lay 1.7-fold (0.24 log units) below the measured number, within the range that was stated.
By their numbers in this assay, from the lowest: compound 1; then compound 3; then compound 2.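

In this assay, the step of a 4.1-fold higher number from compound 1 to compound 3 (0.61 log units; beyond the scatter) shows that chloro in place of hydrogen on an aromatic carbon, ortho to a large group, also moves the number upward, so a second replacement of hydrogen on this ring gives weaker inhibition than the plain phenyl of compound 1. This rise is modest, whereas the trifluoromethyl step a 15-fold higher number from compound 1 to compound 2 (1.18 log units; beyond the scatter) at a different place on the same ring is large, and neither of the two replacements improves on compound 1. No measurement here accounts for the rise seen with chloro.

The compounds shown leave open whether chloro at another place on this ring would give a step of similar size. They also leave open whether an amine or a methoxy group on this same carbon would raise the number as well, or would keep it close to that of compound 1.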